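Swapping Cyano for Fluoro on the Benzyl Group

A few compounds are considered here, and "the series" means these few. Any claim that something is new, unique, unknown or untested is made for them only; others in the source may bear on it.

Three compounds have been measured in an in vitro functional assay on cells for agonist activity at Bombesin receptor subtype-3 (Homo sapiens), read by luminescence and calcium flux; on this read-out higher numbers stand for an effect only at larger amounts of compound and lower numbers for an effect already at smaller amounts:
compound 1, `Cc1ccccc1Cc1cnc(CCc2ccc(-c3ccccc3C(=O)O)cc2)[nH]1`, gives 127 nM;
compound 2, `CCCCc1cnc(C(Cc2ccc(-c3ccccc3C(=O)O)cc2)C(C)C)[nH]1`, gives 4620 nM;
compound 3, `N#Cc1ccc(Cc2cnc(CCc3ccc(-c4ccccc4C(=O)O)cc3)[nH]2)cc1`, gives 5890 nM.

Among these three, compound 3 gives the highest number. Its nearest neighbour is compound 2, and the gap between the two lies within the usual scatter, so the two cannot be told apart. The gap to compound 1 is beyond the scatter.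

Compound 4, `O=C(O)c1ccccc1-c1ccc(CCc2ncc(Cc3ccc(F)cc3)[nH]2)cc1`, is compound 3 with one change: fluoro in place of cyano on an aromatic carbon. Within the data shown here, the only measured step that touches this part of the molecule is a 46-fold higher number from compound 1 to compound 3 (1.67 log units; beyond the scatter). That step changed both the group and its place on the ring at once, so it tells little about exchanging one group for another at the same place. Among the measured compounds shown here, no measured step swaps a single substituent at this position. With the change from cyano to fluoro read as a partial return toward the substituent pattern of compound 1, a lowering of the number is expected, but of modest size and with wide uncertainty. For compound 4 the expected result in this assay is 1500 nM, within a range from 300 nM to 7000 nM, which corresponds to an estimated step of a 3.9-fold lower number from compound 3 to compound 4 (0.59 log units; beyond the scatter).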

Compound 4, half-maximal effective concentration: 1600 nM
For compound 4 the middle estimate is 1.1-fold (0.03 log units) below the measured one; the range from low to high includes it.
By their numbers in this assay, from the lowest: compound 1; then compound 4; then compounds 2 and 3 (each within the scatter of the next).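

In this assay, exchanging cyano for fluoro at this one place, para to a large group, gives a 3.7-fold lower number from compound 3 to compound 4 (0.57 log units; beyond the scatter), so the group on this aromatic carbon matters on its own, with no shift around the ring involved. Removing the cyano group does not close the distance to compound 1, however: 4-fluorophenyl in place of 2-methylphenyl gives a 13-fold higher number from compound 1 to compound 4 (1.10 log units; beyond the scatter), a large step that changes both the group and its place on the ring, and it leaves a sizeable part of the earlier 46-fold higher number from compound 1 to compound 3 (1.67 log units; beyond the scatter) in place. Nothing available explains the size of either step or says what the two groups do here.

Because compound 1 and compound 4 differ in both the group and its place, these compounds cannot show which of the two accounts for the remaining gap; fluoro placed where compound 1 carries its methyl, or methyl placed where compound 4 carries its fluoro, would separate them. Going by these compounds, it also remains open how other groups on this aromatic carbon, such as chloro, methoxy or an amine, would compare with fluoro and cyano.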